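A New Aryl Group on the Sulfonyl Sulfur

A few compounds are considered here, and "the series" means these few. Any claim that something is new, unique, unknown or untested is made for them only; others in the source may bear on it.

In a functional assay on LNCaP cells (Homo sapiens) for antiproliferative activity, read by propidium iodide staining, with a stated time of 96 h (on this read-out higher numbers stand for weaker inhibition and lower numbers for stronger inhibition), compound 2 (`CC(O)(CS(=O)(=O)c1ccc(F)cc1)C(=O)Nc1cccc(S(F)(F)(F)(F)F)c1`) gives 32600 nM as the higher of two numbers, and compound 1 (`CC(O)(CS(=O)(=O)c1ccc(S(F)(F)(F)(F)F)cc1)C(=O)Nc1cccc(S(F)(F)(F)(F)F)c1`) gives 11700 nM as the lower. Compound 3 (`CC(O)(CS(=O)(=O)c1cccc(OC(F)(F)F)c1)C(=O)Nc1cccc(S(F)(F)(F)(F)F)c1`) differs from compound 2 in one place (3-(trifluoromethoxy)phenyl in place of 4-fluorophenyl on a sulfonyl sulfur), with 3-(trifluoromethoxy)phenyl in place of 4-fluorophenyl on a sulfonyl sulfur. Going by the values given here, the only measured step (a 2.8-fold higher number from compound 1 to compound 2 (0.45 log units; beyond the scatter)) also altered the aryl group on that sulfur and was modest. Among the compounds with values here, no measured compound carries the new group, so this guide is loose. A small step toward a lower number is expected (a 1.8-fold lower number from compound 2 to compound 3 (0.26 log units; within the scatter)) here. Compound 3 is estimated at 18000 nM (range 7000 nM to 45000 nM).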

Compound 3, half-maximal inhibitory concentration: 15100 nM
Compound 3: the middle estimate sits 1.2-fold (0.08 log units) above what was measured; measured number inside the range.
By their numbers in this assay, from the lowest: compounds 1 and 3 (each within the scatter of the next); then compound 2.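

Replacing 4-fluorophenyl with 3-(trifluoromethoxy)phenyl on the sulfonyl sulfur gives a 2.2-fold lower number from compound 2 to compound 3 (0.33 log units; beyond the scatter) in this assay. Both aryl groups tried in place of 4-fluorophenyl now give lower numbers than compound 2, so this response is not tied to one replacement, while compound 1 and compound 3 lie within the scatter of each other. No measurement shown here explains the change. Still open, on these data alone, is how this position responds to an aryl group without fluorine, such as unsubstituted phenyl, or to one carrying an amine or a carboxylic acid.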